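A few compounds are considered here, and "the series" means these few. Any claim that something is new, unique, unknown or untested is made for them only; others in the source may bear on it.

Measured compounds in an ADME assay on Vero cells (Chlorocebus sabaeus) for cytotoxicity, read by MTT assay, with a stated time of 72 h; a lower number here means a stronger inhibitor, a higher number a weaker inhibitor:

Compound 1, `Cc1ccccc1NC(=S)NNC(=O)c1cc([N+](=O)[O-])c[nH]1`: in this assay compound 1 gives 462000 nM.
Compound 2, `Cc1ccccc1NC(=S)NNC(=O)c1cc([N+](=O)[O-])cn1C`: in this assay compound 2 gives 471000 nM.
Compound 3, `O=C(NNC(=O)c1cc([N+](=O)[O-])c[nH]1)Nc1ccc(Cl)cc1`: in this assay compound 3 gives 218000 nM.

Compound 3 has the lowest of the three numbers, and its gaps to compound 1 and to compound 2 are both beyond the usual scatter. Compound 1 and compound 2 differ in one place, (methyl in place of hydrogen on an aromatic nitrogen), and that change gave a 1.0-fold higher number from compound 1 to compound 2 (0.01 log units; within the scatter), a step that lies within the scatter of repeated measurements. How the core of compound 3 differs from the core of compound 1 is not broken down here.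

Compound 4, `Cn1cc([N+](=O)[O-])cc1C(=O)NNC(=O)Nc1ccc(Cl)cc1`, has not yet been measured in this assay. It differs from compound 3 by methyl in place of hydrogen on an aromatic nitrogen. This is the same change as the one from compound 1 to compound 2, made on the same place, and among the compounds shown it occurs twice in all. Because the change gave a 1.0-fold higher number from compound 1 to compound 2 (0.01 log units; within the scatter), the step for compound 4 is expected to be no change at the digits printed from compound 3 to compound 4 (within the scatter), that is, no real movement from compound 3. For compound 4 in this assay the number is therefore estimated at 218000 nM, with a likely range from 110000 nM to 440000 nM. This rests on a single earlier pair, so the range is kept wide enough to cover the scatter of the assay itself.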

Compound 4, half-maximal inhibitory concentration: 290000 nM
Estimate against measurement, compound 4: 1.3-fold (0.12 log units) below, and the stated range covers the measured number.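

In this assay, methyl in place of hydrogen on the aromatic nitrogen gave a 1.3-fold higher number from compound 3 to compound 4 (0.12 log units; within the scatter), so on this second core the step again stays within the scatter. Set beside the earlier step, the change carries over from one core to the other with no difference that can be told apart: the same change on two cores in this assay, a 1.0-fold higher number (0.01 log units; within the scatter) from compound 1 to compound 2 and a 1.3-fold higher number (0.12 log units; within the scatter) from compound 3 to compound 4, 1.3-fold (0.12 log units) apart, within the scatter of two such steps. Within the data shown here, this shows only that on these two cores, which differ from each other in more than one place, the swap of hydrogen for methyl leaves the number within the scatter; it does not show that the same would hold on any other core or in any other measurement, and two such small steps give no reason for the result.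

The compounds shown leave open whether a longer chain on that aromatic nitrogen, or a chain ending in an amine or a carboxylic acid, would also stay within the scatter of the compound with hydrogen there. Every compound shown also carries the nitro group, and whether the step would hold with a nitrile in its place remains an open question.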